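The compounds below may be only part of what the source reports. "The series", "measured", "known", "first", "only" and "open" are said of these compounds alone.

Measured compounds:

Compound 1, `Nc1scc(-c2ccc(Br)cc2)c1C(=O)c1ccc(Cl)cc1`: 45%
Compound 2, `Nc1scc(-c2ccc([N+](=O)[O-])cc2)c1C(=O)c1ccc(Cl)cc1`: 47%

In a functional assay on CHO cells for agonist activity at adenosine receptor A1 (Homo sapiens), read by fluorescence and ERK phosphorylation, with stated times of 30 min and 1.5 h, tested at 3 uM (on this read-out lower numbers stand for a weaker effect and higher numbers for a stronger effect at the one concentration tested), compound 1 gives 45%, and compound 2 gives 47%. Of the two numbers shown, the one for compound 2 is the larger, yet the only step between them, a number 2 percentage points higher from compound 1 to compound 2 (within the scatter), lies within the scatter, so the two compounds cannot be told apart on this read-out.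

Compound 3, `COc1ccc(-c2csc(N)c2C(=O)c2ccc(Cl)cc2)cc1`, has not yet been measured. It differs from compound 2 in one place: methoxy in place of nitro on an aromatic carbon

Among the compounds with values here, the single measured step that bears on this position is the one from compound 1 to compound 2, where bromo gave way to nitro, and that step was small, a number 2 percentage points higher from compound 1 to compound 2 (within the scatter). Within the data shown here, no measured pair shows what a methoxy group does at this place, so the expectation rests on the observation that the substituent at this position has so far made little difference. Compound 3 is therefore expected to lie close to compound 2, with a step of about a number 2 percentage points lower from compound 2 to compound 3 (within the scatter), not beyond the scatter. Compound 3 is estimated at 45%, within a range from 30% to 60%.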

Compound 3, a percentage reported as activity, at one concentration (the size of the read-out at that concentration, not a potency): 51%
Compound 3: the middle estimate sits 6 percentage points below what was measured; measured number inside the range.
By their numbers in this assay, from the lowest: compounds 1, 2 and 3 (each within the scatter of the next).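

With methoxy, this place on an aromatic carbon, para to a large group, has now carried three different groups on an otherwise shared core. In this assay, there is a number 4 percentage points higher from compound 2 to compound 3 (within the scatter), and there is a number 6 percentage points higher from compound 1 to compound 3 (within the scatter), so the insensitivity seen earlier for the exchange of bromo and nitro also extends to methoxy, and compounds 1, 2 and 3 cannot be told apart on this read-out. No measurement at hand offers an explanation for this sameness.

The compounds shown leave open whether any other group at this place, such as an amine, a carboxylic acid or a longer chain, would shift the number beyond the scatter, or whether this insensitivity is a feature of bromo, nitro and methoxy alone. They also leave open whether these three compounds would show a stronger or weaker effect than one another at any other concentration, since a result at a single concentration shows only the size of the effect there, and how changes elsewhere on the shared core would alter the picture.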